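A few compounds are considered here, and "the series" means these few. Any claim that something is new, unique, unknown or untested is made for them only; others in the source may bear on it.

Compound 1 (`CC(C)(C)C[C@@H](O)C(=O)N1C[C@@H]2C[C@@H]2[C@H]1C(=O)NCc1cc(Cl)ccc1-n1cnnn1`) gives 25 10^-6 cm/s in an ADME assay on Caco-2 cells (Homo sapiens) for permeability, read by LC-MS, in the apical to basolateral direction, with a stated time of 60 min, at pH 6.5 (on this read-out higher numbers stand for higher permeability and lower numbers for lower permeability), and compound 2 (`CC(C)(C)[C@@H](O)C(=O)N1[C@H](C(=O)NCc2cc(Cl)ccc2-n2cnnn2)C[C@@H]2C[C@@H]21`) gives 16 10^-6 cm/s, within the scatter of compound 1. Compound 3 (`COC(C)(C)[C@@H](O)C(=O)N1N=CC[C@H]1C(=O)NCc1cc(Cl)ccc1-n1cnnn1`) gives 1.7 10^-6 cm/s, lower than compound 1 and beyond the scatter. Compound 4 (`CC(C)(C)OC[C@@H](O)C(=O)N1C[C@@H]2C[C@@H]2[C@H]1C(=O)NCc1cc(Cl)ccc1-n1cnnn1`) is not yet measured. It carries tert-butoxy in place of tert-butyl on a saturated chain carbon, two bonds along the chain from a carbonyl carbon and an oxygen on a saturated carbon. Going by the values given here, no measured pair shows this change, so only a modest downward step is expected in this assay, staying within the scatter. The estimated step runs a 1.9-fold lower number from compound 1 to compound 4 (0.28 log units; within the scatter). For compound 4 the estimate is 13 10^-6 cm/s, with an expected range of 5 10^-6 cm/s to 28 10^-6 cm/s.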

Compound 4, apparent permeability: 17 10^-6 cm/s
Estimate against measurement, compound 4: 1.3-fold (0.12 log units) below, and the stated range covers the measured number.
By their numbers in this assay, from the lowest: compound 3; then compounds 2, 4 and 1 (each within the scatter of the next).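

In this assay, tert-butoxy in place of tert-butyl on a saturated chain carbon, two bonds along the chain from a carbonyl carbon and an oxygen on a saturated carbon, gives a step within the scatter (a 1.5-fold lower number from compound 1 to compound 4 (0.17 log units; within the scatter)). Going by these compounds alone, this is the first one-place comparison, and at this position the added hydrogen-bond acceptor brings no step beyond the scatter. No measurement at hand accounts for the result.

Going by these compounds, whether an amine, a carboxylic acid or a longer chain at this position would stay within the scatter remains open. So does the size of the same change on the cores of compound 2 and compound 3.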